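The compounds below may be only part of what the source reports. "The series", "measured", "known", "first", "only" and "open" are said of these compounds alone.

Three compounds share one core and differ in the chain on a saturated ring carbon and in the halogens on the pendant aryl ring. Compound 1 `CC(=O)NCC[C@@H]1C[C@@H](c2ccc(F)c(F)c2)[C@H](NC(=O)c2cc(-c3c(Cl)cnn3C)c(Cl)o2)CN1` gives 880 nM in a functional assay on OVCAR-8 cells (Homo sapiens) for antiproliferative activity (a higher number here means a weaker inhibitor, a lower number a stronger inhibitor), compound 2 `Cn1ncc(Cl)c1-c1cc(C(=O)N[C@@H]2CN[C@H](CCO)C[C@H]2c2ccc(F)c(F)c2)oc1Cl` gives 460 nM, and compound 3 `C=CC[C@@H]1C[C@@H](c2ccc(Cl)c(Cl)c2)[C@H](NC(=O)c2cc(-c3c(Cl)cnn3C)c(Cl)o2)CN1` gives 990 nM. Of the three, compound 3 shows the highest number; its gap to compound 1 lies within the scatter, while its gap to compound 2 lies beyond it. Compound 4 `Cn1ncc(Cl)c1-c1cc(C(=O)N[C@@H]2CN[C@H](CC(O)CO)C[C@H]2c2ccc(Cl)c(Cl)c2)oc1Cl` is not yet measured and differs from compound 3 by 1,2-dihydroxyethyl in place of vinyl on a saturated chain carbon bound to a saturated ring carbon. Going by the values given here, the one step that bears on this change is the chain change a 1.9-fold lower number from compound 1 to compound 2 (0.28 log units; within the scatter), a small movement toward a lower number. A similarly small step is therefore expected for compound 4, estimated at 600 nM with a range from 250 nM to 1500 nM. The expected step is a 1.7-fold lower number from compound 3 to compound 4 (0.22 log units; within the scatter).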

Compound 4, half-maximal inhibitory concentration: 1610 nM
Beside the measured number, compound 4's estimate is 2.7-fold (0.43 log units) below it; the measured number lies above the stated range.
By their numbers in this assay, from the lowest: compounds 2, 1, 3 and 4 (each within the scatter of the next, the first and the last beyond it).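

Placing 1,2-dihydroxyethyl on this saturated chain carbon in place of vinyl gives a 1.6-fold higher number from compound 3 to compound 4 (0.21 log units; within the scatter) in this assay, so adding these two hydroxy groups to the chain produces no change beyond the scatter. Together with a 1.9-fold lower number from compound 1 to compound 2 (0.28 log units; within the scatter), this makes a second single change of the chain that stays within the scatter. No available evidence accounts for this result. Going by these compounds, whether an amine, a carboxylic acid or a longer chain at this position would give a step beyond the scatter remains open. On these data alone, the effect of the halogens on the pendant aryl ring, apart from any chain change, also remains open.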